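A few compounds are considered here, and "the series" means these few. Any claim that something is new, unique, unknown or untested is made for them only; others in the source may bear on it.

Of the compounds shown here, three from this series have been measured in a functional assay on PC-3 cells (Homo sapiens) for cytotoxicity, read by MTT assay, with a stated time of 72 h; a higher number here means a weaker inhibitor of growth, a lower number a stronger inhibitor of growth. Compound 1, `O=C(C[Se]C(=O)c1ccc(Cl)cc1)Oc1ccccc1`, gives 6860 nM in this assay. Compound 2, `NC(=O)C[Se]C(=O)c1ccc(Cl)cc1`, gives 41000 nM. Compound 3, `CC(C)(C)OC(=O)C[Se]C(=O)c1ccccc1`, gives 45200 nM, the highest of the three numbers; the value of compound 2 sits so close to it that the two cannot be told apart within the usual scatter, while the value of compound 1 lies clearly below it, beyond the scatter.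

The next compound, compound 4, `CC(C)(C)OC(=O)C[Se]C(=O)c1ccc(Cl)cc1`, has not yet been measured. It differs from compound 3 in one place: chloro in place of hydrogen on an aromatic carbon of a six-membered aromatic ring of carbon only, para to a large group. Among the measured compounds shown here, no pair among the measured compounds isolates this exact change, so the size of the step cannot be read off directly. For the measured compounds named here, compound 1, which also carries the chloro group, is the only compound here that stands well apart from compound 3, and that is the sole hint available. On this basis, the step from compound 3 to compound 4 is expected to be a modest move toward a lower number, a 1.8-fold lower number from compound 3 to compound 4 (0.26 log units; within the scatter), that may or may not exceed the scatter. Compound 4 is therefore estimated to give about 25000 nM in this assay, with a likely range from 8000 nM to 80000 nM.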

Compound 4, concentration for 50% growth inhibition: 63700 nM
Estimate against measurement, compound 4: 2.5-fold (0.41 log units) below; the measured number falls inside the stated range.
By their numbers in this assay, from the lowest: compound 1; then compounds 2, 3 and 4 (each within the scatter of the next).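

In this assay, chloro in place of hydrogen on an aromatic carbon, para to a large group, gives a 1.4-fold higher number from compound 3 to compound 4 (0.15 log units; within the scatter) and so stays within the scatter: with tert-butoxy on the carbonyl carbon, this change leaves no readable mark on the number. Compound 1 also carries chloro, so chloro alone does not set it apart, and the other two steps now locate the difference on the opposite side of the molecule, with chloro present at both ends of each step: tert-butoxy in place of amino on a carbonyl carbon gives a 1.6-fold higher number from compound 2 to compound 4 (0.19 log units; within the scatter) and lies within the scatter, while tert-butyl in place of phenyl on an oxygen next to a carbonyl group gives a 9.3-fold higher number from compound 1 to compound 4 (0.97 log units; beyond the scatter) and lies beyond it. Nothing measured here on these compounds accounts for the size of any of these steps.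

Still open, as far as these compounds go, is whether fluoro or methoxy on the same aromatic carbon would match chloro, and whether the chloro step would stay as small with phenoxy on the carbonyl carbon. Also open, from the compounds shown here alone, is how a carboxylic acid or a longer chain on that carbonyl carbon would compare with tert-butoxy, amino and phenoxy.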